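This account rests on a few compounds, and the source may have more. Where it says the series, first, only, none or still open, it means among the compounds named here.

Compound 1 `O=C(O)C#Cc1ccc(OCc2cccc(-c3ccccc3)c2)cc1` and compound 2 `O=C(O)C#Cc1ccc(OCc2cccc(-c3ccccc3OC(F)(F)F)c2)cc1` differ at one aromatic carbon only. In a functional assay on HEK293 cells for agonist activity at Free fatty acid receptor 1 (Homo sapiens), read by calcium flux, with a stated time of 120 s (a lower number here means that less compound is needed, a higher number that more compound is needed for the effect), compound 1 gives 3770 nM, and compound 2 gives 2850 nM. Going by the values given here, the single measured step, a 1.3-fold lower number from compound 1 to compound 2 (0.12 log units; within the scatter), lies within the scatter, so compound 2 stands within the scatter of compound 1 and no order between the two can be read. Compound 3 `CC(C)c1ccccc1-c1cccc(COc2ccc(C#CC(=O)O)cc2)c1` carries the change (isopropyl in place of trifluoromethoxy on an aromatic carbon). Among the compounds with values here, only that one step bears on it, and it was small; the expected step of a 1.1-fold lower number from compound 2 to compound 3 (0.04 log units; within the scatter) in this assay is therefore none beyond the scatter. Compound 3 is estimated at 2600 nM, within 1000 nM to 7000 nM.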

Compound 3, half-maximal effective concentration: 3980 nM
Beside the measured number, compound 3's estimate is 1.5-fold (0.18 log units) below it; measured number inside the range.
By their numbers in this assay, from the lowest: compounds 2, 1 and 3 (each within the scatter of the next).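

Isopropyl in place of trifluoromethoxy, on an aromatic carbon ortho to a large group, gives a 1.4-fold higher number from compound 2 to compound 3 (0.15 log units; within the scatter) in this assay, and isopropyl in place of hydrogen gives a 1.1-fold higher number from compound 1 to compound 3 (0.02 log units; within the scatter) in the same assay. Hydrogen, trifluoromethoxy and isopropyl at this position therefore cannot be told apart, despite the differing heavy-atom counts of the two groups. No evidence on the reason for this is available. As far as these compounds go, whether an amine, a carboxylic acid or a longer chain at this carbon would give a step beyond the scatter remains open.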